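The compounds below may be only part of what the source reports. "The series", "measured", "known", "first", "only" and "open" are said of these compounds alone.

Compound 1 `COc1ccc(/C=N/NC(=O)Nc2cc3c(Nc4ccc(F)c(Cl)c4)ncnc3cc2O[C@H]2CCOC2)c(OC)c1OC`: 33800 nM
Compound 2 `O=C(N/N=C/c1cc(Br)c(O)c(Br)c1)Nc1cc2c(Nc3ccc(F)c(Cl)c3)ncnc2cc1O[C@H]1CCOC1`: 5910 nM

Going by the values given here, in a functional assay on MCF7 cells (Homo sapiens) for cytotoxicity, read by MTT assay, with a stated time of 72 h (a lower number here means a stronger inhibitor, a higher number a weaker inhibitor), compound 2 has the lower of the two numbers so far, 5910 nM. Compound 3 `CCN(CC)c1ccc(/C=N/NC(=O)Nc2cc3c(Nc4ccc(F)c(Cl)c4)ncnc3cc2O[C@H]2CCOC2)c(O)c1` carries 4-(diethylamino)-2-hydroxyphenyl in place of 3,5-dibromo-4-hydroxyphenyl on a carbon with a double bond to nitrogen. Among the compounds with values here, only one measured step changes this same place: a 5.7-fold lower number from compound 1 to compound 2 (0.76 log units; beyond the scatter), a modest change. Within the data shown here, no measured compound carries the new group, so the direction is uncertain. The expected step is a 1.4-fold higher number from compound 2 to compound 3 (0.13 log units; within the scatter), which is no change beyond the scatter. For compound 3 the estimated value is 8000 nM, with an expected range of 2000 nM to 30000 nM.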

Compound 3, half-maximal inhibitory concentration: 15600 nM
The estimate for compound 3 lay 2.0-fold (0.29 log units) below the measured number; the measured number falls inside the stated range.
By their numbers in this assay, from the lowest: compound 2; then compound 3; then compound 1.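

In this assay, placing 4-(diethylamino)-2-hydroxyphenyl on the carbon with a double bond to nitrogen gives a 2.6-fold higher number from compound 2 to compound 3 (0.42 log units; beyond the scatter) but also a 2.2-fold lower number from compound 1 to compound 3 (0.34 log units; beyond the scatter) so this position separates three groups, with compound 3 lying between the other two. Compound 2 and compound 3 both carry a hydroxyl on the ring yet still differ beyond the scatter, so that hydroxyl alone does not set the number. Nothing measured here explains these differences.

Whether the two bromines account for the lower number of compound 2 stays open. So does the effect of a plain phenyl group or a carboxylic acid on the ring.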